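Swapping Dimethylamino for Methoxy on a Lipoxygenase Inhibitor

The source may hold more compounds than are shown below. What is called first, only, known or untested is meant among the compounds shown, and "the series" means these compounds.

Of the compounds shown here, three sharing one core have been tested in an assay on cells for inhibition of Polyunsaturated fatty acid 5-lipoxygenase (Homo sapiens), read by HPLC, with stated times of 15 min and 10 min; a higher number here means a weaker inhibitor, a lower number a stronger inhibitor. Compound 1 `Clc1ccc2nc(-c3ccc(N4CCCCC4)cc3)c(NC3CCCCC3)n2c1` gives 140 nM. Compound 2 `Oc1ccc(-c2nc3ccc(Br)cn3c2NC2CCCCC2)cc1` gives 1100 nM. Compound 3 `Cc1ccc2nc(-c3ccc(N(C)C)cc3)c(NC3CCCCC3)n2c1` gives 600 nM, the second highest of the three numbers; its value and that of compound 2 lie within the usual scatter of each other, while compound 1 gives a number lower than compound 3 by more than the scatter.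

Compound 4 `COc1ccc(-c2nc3ccc(C)cn3c2NC2CCCCC2)cc1` is not yet measured. It differs from compound 3 in one place: methoxy in place of dimethylamino on an aromatic carbon. Among the measured compounds shown here, no measured pair shows this exact change, so the expectation rests only on the spread among compounds 1 to 3. A small step toward a higher number is expected, a 1.5-fold higher number from compound 3 to compound 4 (0.18 log units; within the scatter), not clearly beyond the scatter. Compound 4 is therefore expected to give about 900 nM, within a range from 350 nM to 2500 nM.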

Compound 4, half-maximal inhibitory concentration: 1300 nM
The estimate for compound 4 lay 1.4-fold (0.16 log units) below the measured number, and the stated range covers the measured number.
By their numbers in this assay, from the lowest: compound 1; then compounds 3, 2 and 4 (each within the scatter of the next, the first and the last beyond it).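

In this assay, among the compounds shown here, the first comparison that changes only this group shows that it matters: methoxy in place of dimethylamino on an aromatic carbon gives a 2.2-fold higher number from compound 3 to compound 4 (0.34 log units; beyond the scatter) and takes the number modestly past the scatter. Within this single pair, dimethylamino therefore goes with the stronger inhibitor. No available evidence explains the step.

On these data alone, whether the change has the same effect with other groups on the shared core remains open. So does how a longer chain such as ethoxy, or a carboxylic acid, would compare at this position.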